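Tether-swapped neopentyl ketones: removing the tert-butyl group

The compounds below may be only part of what the source reports. "The series", "measured", "known", "first", "only" and "open" are said of these compounds alone.

Measured compounds:
- compound 1, `Cc1c(OCCCCOc2ccc(F)c(C(=O)O)c2)ccc(C(=O)CC(C)(C)C)c1O`, in an assay on HEK293 cells for positive allosteric modulation of metabotropic glutamate receptor 2 (Rattus norvegicus), read by thallium flux, with a stated time of 2.5 min (on this read-out lower numbers stand for smaller maximal responses and higher numbers for larger maximal responses), gives 94.6%
- compound 2, `Cc1c(OCCCCOc2ccc(C(=O)CC(C)(C)C)c(O)c2C)cccc1C(=O)O`, in this assay gives 95.8%
- compound 3, `CC(=O)c1ccc(OCCCCOc2ccc(F)c(C(=O)O)c2)c(C)c1O`, in this assay gives 75.5%

The two cores differ as follows: 3-carboxy-2-methylphenyl in place of 3-carboxy-4-fluorophenyl on an oxygen on a saturated carbon. On this swap the readout barely moves, a number 1.2 percentage points higher from compound 1 to compound 2 (within the scatter), so the two cores behave alike on the ketone-bearing side as far as these two compounds show.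

The other change seen so far is hydrogen in place of tert-butyl on a saturated chain carbon bound to a carbonyl carbon. It costs a modest amount of maximal response, a number 19.1 percentage points lower from compound 1 to compound 3 (beyond the scatter).

Compound 4, `CC(=O)c1ccc(OCCCCOc2cccc(C(=O)O)c2C)c(C)c1O`, has not yet been measured in this assay. Going by the values given here, it differs from compound 2 by hydrogen in place of tert-butyl on a saturated chain carbon bound to a carbonyl carbon, which is the same change, at the same place, as the one made from compound 1 to compound 3; it occurs twice among the four compounds. Among the compounds with values here, since the core swap left the readout essentially unchanged, as a number 1.2 percentage points higher from compound 1 to compound 2 (within the scatter) shows, the one measured example of removing the tert-butyl, a number 19.1 percentage points lower from compound 1 to compound 3 (beyond the scatter), is taken as the guide. For compound 4 the corresponding step is expected to be about that size, namely a number 18.8 percentage points lower from compound 2 to compound 4 (beyond the scatter). That expectation rests on a single measured pair, compound 1 and compound 3, so it carries the uncertainty of one example. Compound 4 is therefore expected to give about 77% in this assay, with the range 62% to 90%.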

Compound 4, largest response reached (reported as percent of maximum), in percent of the reference or control that the assay uses: 79.2%
For compound 4 the middle estimate is 2.2 percentage points below the measured one; the range from low to high includes it.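

On the core of compound 2, putting hydrogen in place of tert-butyl, which turns the neopentylcarbonyl into an acetyl, gives a number 16.6 percentage points lower from compound 2 to compound 4 (beyond the scatter) in this assay. Set beside the same change on the core of compound 1, the step is of matching size: the same change on two cores in this assay, a number 19.1 percentage points lower (beyond the scatter) from compound 1 to compound 3 and a number 16.6 percentage points lower (beyond the scatter) from compound 2 to compound 4, 2.5 percentage points apart, within the scatter of two such steps Between these two cores, then, the loss of maximal response carries over with no difference that can be told from the scatter, though this rests on only two matched pairs in one assay and shows neither that the step would hold on a further core nor what lies behind the loss.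

The compounds shown go straight from the neopentyl ketone to the methyl ketone, so it remains open how the response behaves with an intermediate group on the ketone, such as an ethyl or an isopropyl, or with a ring-bearing one, such as cyclopropylmethyl. Also open, going by these compounds, is whether the step keeps its size when the carboxylic acid shared by all four compounds gives way to an amide or a tetrazole, or when the tether between the two aryl ethers is replaced by a longer chain.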